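The compounds below may be only part of what the source reports. "The series", "measured", "known", "first", "only" and "open" are said of these compounds alone.

Measured so far in a functional assay on MC-38 cells (Mus musculus) for antiproliferative activity (a higher number here means a weaker inhibitor, a lower number a stronger inhibitor), for antiproliferative activity:

Compound 1 `O=S(=O)(Nc1cccc2cc[nH]c12)c1ccc(Cl)cc1` gives 7 ug/mL
Compound 2 `Nc1ccc(S(=O)(=O)Nc2cccc3cc[nH]c23)cc1` gives 6.1 ug/mL

Compound 2 stands level with compound 1 within the scatter, so the two cannot be ranked. The next structure, compound 3 `Nc1ccc(S(=O)(=O)Nc2cccc3c(Cl)c[nH]c23)cc1`, differs from compound 2 by chloro in place of hydrogen on an aromatic carbon, counted as chloro in place of hydrogen on an aromatic carbon in all. Among the measured compounds shown here, only one measured step is available, a 1.1-fold lower number from compound 1 to compound 2 (0.06 log units; within the scatter), and it lies within the scatter. That step, amino in place of chloro on an aromatic carbon, concerns another place in the molecule and so bears on the new change only loosely. For the measured compounds named here, no measured compound carries a change at the new place. No step beyond the scatter is therefore expected, in either direction. The estimate is a 1.2-fold lower number from compound 2 to compound 3 (0.09 log units; within the scatter) and that expected step stays within the scatter. Compound 3 is estimated at 5 ug/mL and expected to fall between 2.2 ug/mL and 11 ug/mL.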

Compound 3, half-maximal inhibitory concentration: 0.23 ug/mL
The estimate for compound 3 lay 22-fold (1.34 log units) above the measured number; the whole stated range lies above it.
By their numbers in this assay, from the lowest: compound 3; then compounds 2 and 1 (each within the scatter of the next).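

In this assay, chloro in place of hydrogen on an aromatic carbon of the five-membered aromatic ring, two ring bonds from the ring nitrogen, gives a 27-fold lower number from compound 2 to compound 3 (1.42 log units; beyond the scatter) and so shows that this position responds strongly to one added atom. The earlier change, at another place in the molecule, gave only a 1.1-fold lower number from compound 1 to compound 2 (0.06 log units; within the scatter) and revealed nothing about this position, which carried hydrogen in both earlier compounds. Nothing available here accounts for the size of the new step.

The compounds shown leave open whether the gain belongs to chloro itself or would also appear with fluoro, bromo, methyl or a nitrile at this place. They also leave open whether the step would keep its size with chloro instead of the amino group at the other end of the molecule, as in compound 1.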